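A few compounds are considered here, and "the series" means these few. Any claim that something is new, unique, unknown or untested is made for them only; others in the source may bear on it.

This account follows one change on the amine nitrogen in a ring of a shared core, from compound 2 to compound 4, judged in a functional assay on HL-60 cells (Homo sapiens) for inhibition, read by MTT assay, with a stated time of 72 h; on this read-out higher numbers stand for weaker inhibition and lower numbers for stronger inhibition. Of the compounds shown here, three have been measured so far. Compound 1 `CCc1nc(-c2cccc(F)c2)c(C(=O)N2CCN(c3cccc(OC)c3)CC2)o1` gives 201 nM in this assay. Compound 3 `Cc1nc(-c2ccc(F)cc2)c(C(=O)N2CCN(c3ccc(Cl)cc3)CC2)o1` is reported in this assay as "not active" (no number reported), with no number behind it. Going by the values given here, compound 2 `Cc1ccc(N2CCN(C(=O)c3oc(C)nc3-c3ccccc3)CC2)cc1` stands in this assay at > 1000 nM, and this is a limit of the assay rather than a number, the one value of the three that sits at the limit of > 1000 nM in this assay, at which 1 of the 3 values shown sits. So compound 2 stands, on the numbers shown, as a limit and not a measured number, alongside compound 3, whose entry likewise carries no number.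

Compound 4 `Cc1cc(C)cc(N2CCN(C(=O)c3oc(C)nc3-c3ccccc3)CC2)c1` has not yet been measured in this assay. The change is 3,5-dimethylphenyl in place of 4-methylphenyl on an amine nitrogen in a ring, and the rest of the core is untouched. Among the compounds with values here, no step between two measured compounds has been recorded, so nothing in the data fixes how large such a change turns out in this assay. With compound 2 known only as a limit, the account expects the step that the limit leaves unreadable from compound 2 to compound 4 to stay within the scatter, with no direction that the data could support. Compound 4 is therefore estimated at 3000 nM in this assay, within a range from 700 nM to 20000 nM, with a fair chance that only a limit is again reported.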

Compound 4, half-maximal inhibitory concentration: 34.5 nM
Compound 4: middle estimate off by 87-fold (1.94 log units), on the high side; the measured number lies below the stated range.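

In this assay, going by these compounds alone, the change on the amine nitrogen in a ring gives the first step that can be read, and it is large: an at least 28-fold lower number from compound 2 to compound 4 (1.46 log units; beyond the scatter). Compound 2 is entered only as a limit and not as a number: the limit of > 1000 nM in this assay, at which 1 of the 4 values shown sits. The earlier compounds shown here showed no effect of any single change, whereas this pair shows that the number at this position can move well beyond the scatter, even though the leaving 4-methylphenyl and the entering 3,5-dimethylphenyl are both a six-membered aromatic ring of carbon only, with no hydrogen-bond donors or acceptors and no net charge.

All other steps among the compounds shown cannot be read, since compound 1 and compound 3 differ from the rest in more than one place, so it stays open whether this 3,5-dimethylphenyl effect carries over to other substituents elsewhere on the shared core. Also open, as far as these compounds go, is how the read-out would respond if an amine or a carboxylic acid stood on this aromatic ring in place of the methyl groups.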